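The source may hold more compounds than are shown below. What is called first, only, known or untested is meant among the compounds shown, and "the series" means these compounds.

The set consists of compound 1 `O=C1NC(O)(CCn2cnc3ccnc(Cl)c32)C(OCc2ccccc2)=C1OCc1ccccc1`, compound 3 `O=C1NC(O)(CCn2cnc3cc[nH]c3c2=O)C(OCc2ccccc2)=C1OCc1ccccc1`, compound 2 `O=C1O/C(=C\Cn2cnc3c(F)nc(F)c(Cl)c32)C(OCc2ccccc2)=C1OCc1ccccc1` and the still unmeasured compound 4 `O=C1O/C(=C\Cn2cnc3ncc(Br)c-3c2)C(OCc2ccccc2)=C1OCc1ccccc1`. In a functional assay on HeLa cells (Homo sapiens) for antiproliferative activity, read by MTT assay, with a stated time of 72 h (on this read-out higher numbers stand for weaker inhibition and lower numbers for stronger inhibition), compound 1 gives 21000 nM. In the same assay compound 3 gives 92000 nM, and the change between them is a 4.4-fold higher number from compound 1 to compound 3 (0.64 log units; beyond the scatter). Compound 2 is known only as a limit of the assay: in this assay compound 2 gives > 100000 nM, so it sits at the limit of > 100000 nM in this assay, at which 1 of the 3 values shown sits.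

Compound 4 differs from compound 2 in a single place, (a group of 10 heavy atoms (6 carbon, 3 nitrogen, 1 bromine; one five-membered aromatic ring with 1 hetero atom, one six-membered aromatic ring with 2 hetero atoms) in place of a group of 12 heavy atoms (6 carbon, 3 nitrogen, 2 fluorine, 1 chlorine; one five-membered aromatic ring with 2 hetero atoms, one six-membered aromatic ring with 1 hetero atom), on a saturated chain carbon bound to a double-bonded chain carbon). Going by the values given here, the only measured step that runs along the same line is the exchange of one bicyclic heteroaryl for another in going from compound 1 to compound 3, where the number rose by a 4.4-fold higher number from compound 1 to compound 3 (0.64 log units; beyond the scatter), a weakening beyond the scatter. Among the compounds with values here, compound 2 already stands at the limit, so any step of that kind, or even no step at all, leaves compound 4 at or past the limit, with the direction, if anything, toward a higher number. Compound 4 is therefore expected to give about 200000 nM in this assay, within a range from 60000 nM to 700000 nM. The expected step is a step that the limit leaves unreadable from compound 2 to compound 4, most likely reported again only as a limit.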

Compound 4, half-maximal inhibitory concentration: 17000 nM
Compound 4: middle estimate off by 12-fold (1.07 log units), on the high side; the measured number lies below the stated range.
By their numbers in this assay, from the lowest: compounds 4 and 1 (each within the scatter of the next); then compound 3. At a limit, above all of these: compound 2.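

The exchange on a saturated chain carbon bound to a double-bonded chain carbon is not neutral: in this assay, it gives an at least 5.8-fold lower number from compound 2 to compound 4 (0.76 log units; beyond the scatter). The earlier measured exchange of one bicyclic heteroaryl for another had gone the opposite way, with a 4.4-fold higher number from compound 1 to compound 3 (0.64 log units; beyond the scatter), so the direction of such an exchange is not fixed across the compounds shown, although that step sits on a different chain and core. Compound 2 is a limit and not a number, so the full size of the new step cannot be read: the limit of > 100000 nM in this assay, at which 1 of the 4 values shown sits.

The compounds shown leave open which part of the exchange goes with the lower number, since the bromine, the loss of the two fluorine atoms and the chlorine, and the change in the rings all arrive together; a methyl group or a nitrile in place of the bromine on the entering group would separate these. They also leave open whether the entering group would give a similar number on the core and chain of compound 1, which carries a hydroxyl group and the amide hydrogen.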